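Methoxy added to the aromatic ring of compound 2

A few compounds are considered here, and "the series" means these few. Any claim that something is new, unique, unknown or untested is made for them only; others in the source may bear on it.

Two compounds have numbers in a functional assay on MCF7 cells (Homo sapiens) for cytotoxicity, read by fluorescence and sulforhodamine B assay; a higher number here means a weaker inhibitor, a lower number a stronger inhibitor. Compound 1 `COc1ccc(/C=C/Cc2ccc(O)c(OC)c2OC)cc1O` gives 74300 nM there. Compound 2 `O=C1C=C[C@](O)(C/C=C/c2ccccc2)CC1` gives 54400 nM in this assay, the lowest of the two numbers, though the gap to compound 1 lies within the scatter, so no order between them can be claimed. Compound 3 `COc1ccccc1/C=C/C[C@@]1(O)C=CC(=O)CC1` differs from compound 2 by methoxy in place of hydrogen on an aromatic carbon. Among the compounds with values here, no pair of measured compounds shows this change, so its weight is unknown. A step of a 1.2-fold lower number from compound 2 to compound 3 (0.08 log units; within the scatter) in this assay is expected, staying within the scatter. Compound 3 is accordingly estimated at 45000 nM, with a range from 15000 nM to 130000 nM.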

Compound 3, half-maximal inhibitory concentration: 48800 nM
Compound 3: the middle estimate sits 1.1-fold (0.04 log units) below what was measured; the range from low to high includes it.
By their numbers in this assay, from the lowest: compounds 3, 2 and 1 (each within the scatter of the next).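

Methoxy in place of hydrogen on an aromatic carbon, ortho to a large group, now has a measured size: in this assay the change gives a 1.1-fold lower number from compound 2 to compound 3 (0.05 log units; within the scatter), so this position accepts methoxy without a readable shift in the number. Nothing at hand offers an explanation for this result.

Open remains whether an amine, a carboxylic acid or a longer alkoxy chain on this aromatic carbon would move the number beyond the scatter. A single step also cannot tell whether methoxy behaves alike on another core.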